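Pyridinyl for Pyrazolyl on the Amide Nitrogen

The compounds below may be only part of what the source reports. "The series", "measured", "known", "first", "only" and "open" are said of these compounds alone.

Measured in an assay on HEK293 cells for agonist activity at transient receptor potential cation channel subfamily M member 8 (Homo sapiens), read by fluorescence and calcium flux, with a stated time of 15 min; a higher number here means that more compound is needed for the effect, a lower number that less compound is needed:
compound 1 `Cc1ccc(OCC(=O)N(Cc2cccs2)c2ccn[nH]2)cc1`: 0.2 nM
compound 2 `COc1ccc(OCC(=O)N(Cc2cccs2)c2ccn[nH]2)cc1`: 3.7 nM
compound 3 `CCN1C(=O)C(Oc2ccc(C)cc2)C1c1cccs1`: "active" (no number reported)

Compound 1 holds the lowest of the two numbers shown. Its nearest neighbour is compound 2, and the step of a 19-fold higher number from compound 1 to compound 2 (1.27 log units; beyond the scatter) lies beyond the scatter. Compound 3 is reported only as active, without a number.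

Compound 4 `Cc1ccc(OCC(=O)N(Cc2cccs2)c2cccnc2)cc1` has not yet been measured in this assay. It differs from compound 1 in a single place: pyridin-3-yl in place of 1H-pyrazol-5-yl on an amide-type nitrogen. Among the measured compounds shown here, no measured step bears directly on this change. For the measured compounds named here, the only measured step, a 19-fold higher number from compound 1 to compound 2 (1.27 log units; beyond the scatter), concerns a substituent on an aromatic carbon rather than the group on the amide-type nitrogen, and compound 3 has a different core and no number. The group that leaves holds a hydrogen-bond donor and the group that enters holds none; what that means for the number is not shown by any measured pair. A higher number than that of compound 1 is expected, with a wide range.

Compound 4 is expected to give 5 nM in this assay, within 0.5 nM to 100 nM. The expected step is a 25-fold higher number from compound 1 to compound 4 (1.40 log units; beyond the scatter).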

Compound 4, half-maximal effective concentration: 198 nM
The estimate for compound 4 lay 40-fold (1.60 log units) below the measured number; the measured number lies above the stated range.
By their numbers in this assay, from the lowest: compound 1; then compound 2; then compound 4.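

Among the compounds shown here, at the amide-type nitrogen of compound 1, pyridin-3-yl in place of 1H-pyrazol-5-yl gives a 990-fold higher number from compound 1 to compound 4 (3.00 log units; beyond the scatter) in this assay and so shows, as no earlier pair could, that the number depends strongly on the group at this position. This step is larger than a 19-fold higher number from compound 1 to compound 2 (1.27 log units; beyond the scatter), the only other single change shown on compound 1. The change alters both the ring size and the count of hydrogen-bond donors, and no available evidence shows which of these differences matters, or why the number rises.

The compounds shown leave open whether a five-membered ring that keeps the ring hydrogen, such as 1H-imidazol-2-yl, would hold a low number at this position. They also leave open whether a plain phenyl would behave like pyridin-3-yl.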